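Removing a Methoxy Group: What to Expect for Compound 4

The source may report more compounds than this note shows. Statements on the series, on what has been measured and on what is new or still open speak of the compounds shown alone.

Measured in a functional assay on MHCC97H cells (Homo sapiens) for antiproliferative activity, read by MTT assay, with a stated time of 48 h; on this read-out lower numbers stand for stronger inhibition and higher numbers for weaker inhibition:
Compound 1, `COc1ccc2c(/C=C/C(=O)c3cc(OC)c(OC)c(SC)c3)cn(C)c2c1`, gives 122 nM.
Compound 2, `COc1ccc2c(/C=C(\C)C(=O)c3cc(OC)c(OC)c([Se]C)c3)c[nH]c2c1`, gives 6 nM.
Compound 3, `COc1cc(C(=O)/C(C)=C/c2c[nH]c3ccccc23)cc([Se]C)c1OC`, gives 18 nM.

Of these three, compound 1 has the highest number and compound 2 the lowest. Compound 2 and compound 3 share one core and differ in a single place: hydrogen in place of methoxy on an aromatic carbon. That change gave a 3.0-fold higher number from compound 2 to compound 3 (0.48 log units; beyond the scatter), a worsening that lies beyond the usual scatter. Compound 4, `COc1cc(C(=O)/C=C/c2cn(C)c3ccccc23)cc(SC)c1OC`, has not yet been measured in this assay; it arises from compound 1 through the same change at the same place: hydrogen in place of methoxy on an aromatic carbon. The cores of compound 1 and compound 2 differ in more than one place, and that difference is not broken down here.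

Resting on a 3.0-fold higher number from compound 2 to compound 3 (0.48 log units; beyond the scatter), the step from compound 1 to compound 4 is expected to be of similar size, about a 3.0-fold higher number from compound 1 to compound 4 (0.48 log units; beyond the scatter). Among the measured compounds shown here, only one earlier example supports this, and the cores are not the same, so the expected range is kept wide. Compound 4 is therefore estimated to give about 370 nM, most likely between 150 nM and 900 nM.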

Compound 4, half-maximal inhibitory concentration: 150 nM
Beside the measured number, compound 4's estimate is 2.5-fold (0.39 log units) above it; the range from low to high includes it.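

In this assay, swapping the methoxy group for hydrogen on the core of compound 1 gave a 1.2-fold higher number from compound 1 to compound 4 (0.09 log units; within the scatter) and so left no change that can be told apart from repeat-measurement scatter. Set beside the earlier step, the result does not show that the change behaves differently on the two cores: the same change on two cores in this assay, a 3.0-fold higher number (0.48 log units; beyond the scatter) from compound 2 to compound 3 and a 1.2-fold higher number (0.09 log units; within the scatter) from compound 1 to compound 4, 2.4-fold (0.39 log units) apart, within the scatter of two such steps. It also does not show that the change carries over reliably, since one step lies beyond the scatter and the other within it, and two examples are too few to settle the matter when the cores differ in more than one place.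

The compounds shown leave open how the change would behave on further cores, where more examples could show whether the two steps truly match. They also leave open what other groups at this place, such as a hydroxyl group, a fluorine atom or an amine, would do in this assay.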